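The compounds below may be only part of what the source reports. "The series", "measured", "known", "first", "only" and "open" are said of these compounds alone.

Compound 2 `COc1cc(Cl)cc(-c2nn(-c3cccc(NC(=O)Nc4ccc(Cl)c(C(F)(F)F)c4)c3)cc2-c2ccncc2)c1` was tested in a functional assay on SF-295 cells (Homo sapiens) for inhibition, read by sulforhodamine B assay, with a stated time of 48 h, tested at 10 uM (a higher number here means a weaker effect of the compound at the concentration tested, a lower number a stronger effect), and gave -7.48%. Within the data shown here, its closest neighbour is compound 1 `COc1cc(Cl)cc(-c2nn(-c3cccc(NC(=O)Nc4cccc(C(F)(F)F)c4)c3)cc2-c2ccncc2)c1`, which in this assay gave -7.87%; the one step measured so far, a number 0.4 percentage points higher from compound 1 to compound 2 (within the scatter), stays within the scatter, so compound 2 stands at a number that cannot be told apart from compound 1. Compound 3 `O=C(Nc1cccc(-n2cc(-c3ccncc3)c(-c3cc(O)cc(Cl)c3)n2)c1)Nc1ccc(Cl)c(C(F)(F)F)c1` differs from compound 2 in one place: hydrogen in place of methyl on an oxygen on an aromatic ring. Among the measured compounds shown here, none of the measured steps touches this oxygen, so there is no direct guide; the only step known, from a chloro for a hydrogen on an aromatic carbon, left the number essentially unchanged. On that basis the step of a number 0.5 percentage points higher from compound 2 to compound 3 (within the scatter) is expected to stay within the scatter, and compound 3 is estimated to give -7% in this assay, with a range from -25% to 12%.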

Compound 3, a percentage reported as activity, at one concentration (the size of the read-out at that concentration, not a potency): 14.3%
Compound 3: middle estimate off by 21.3 percentage points, on the low side, outside the stated range (above it).
By their numbers in this assay, from the lowest: compounds 1 and 2 (each within the scatter of the next); then compound 3.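

In this assay, replacing methoxy with hydroxy on the 3-chloro-5-methoxyphenyl ring gives a number 21.8 percentage points higher from compound 2 to compound 3 (beyond the scatter), which on this scale means a weaker effect at the concentration tested. Among these compounds, this is the first measured step to go beyond the scatter, since the chloro step on the other aromatic ring, a number 0.4 percentage points higher from compound 1 to compound 2 (within the scatter), did not, so removing this one methyl is enough to change the read-out. Nothing available explains why the number moves at this oxygen.

With only methoxy and hydroxy at this place, one pair cannot show whether the change follows from gaining the free hydroxy or from losing the methyl. Going by these compounds, an ethoxy group or an amine at the same place would help separate the two, and the effect of the same change on compound 1 also remains open.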